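The compounds below may be only part of what the source reports. "The series", "measured", "known", "first", "only" and "open" are said of these compounds alone.

Among the compounds with values here, compound 3 `O=C(Nc1ccc(Br)cc1)c1csc(Cc2c(Cl)cccc2Cl)n1` is the one member of this small set with a numerical result: in an assay on CHO cells, read by calcium flux (a higher number here means a weaker inhibitor, a lower number a stronger inhibitor), compound 3 gives 460 nM. Compound 1 `O=C(Nc1ccccc1)c1csc(Cc2c(Cl)cccc2Cl)n1` gives > 4000 nM, which is a limit of the assay rather than a number. Compound 2 `COc1ccc(NC(=O)c2csc(Cc3c(Cl)cccc3Cl)n2)cc1` likewise gives > 4000 nM, again a limit. The two readable steps are an at least 8.6-fold lower number from compound 1 to compound 3 (0.93 log units; beyond the scatter) and an at least 8.6-fold lower number from compound 2 to compound 3 (0.93 log units; beyond the scatter); both are bounded by the limit of > 4000 nM in this assay, at which 2 of the 3 values shown sit, and show only that bromo at this position helps, not by how much. Compound 4 `O=C(Nc1ccc(C(F)(F)C(F)(F)F)cc1)c1csc(Cc2c(Cl)cccc2Cl)n1` differs from compound 3 by 1,1,2,2,2-pentafluoroethyl in place of bromo on an aromatic carbon. Within the data shown here, no measured step tests a group of this kind, so compound 4 is expected to stay close to compound 3, with a step of a 1.0-fold lower number from compound 3 to compound 4 (0.01 log units; within the scatter) lying within the scatter. Compound 4 is therefore estimated at 450 nM, between 150 nM and 1500 nM.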

Compound 4, half-maximal inhibitory concentration: 350 nM
Compound 4: the middle estimate sits 1.3-fold (0.11 log units) above what was measured; low and high end bracket the measured number.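

Bromo is not the only group that serves on this aromatic carbon: 1,1,2,2,2-pentafluoroethyl, with 7 heavy atoms in place of 1, gives a 1.3-fold lower number from compound 3 to compound 4 (0.12 log units; within the scatter), so the exchange leaves the result unchanged within the usual scatter. This second group also separates clearly from hydrogen, with an at least 11-fold lower number from compound 1 to compound 4 (1.05 log units; beyond the scatter), and from methoxy, with an at least 11-fold lower number from compound 2 to compound 4 (1.05 log units; beyond the scatter). Those two steps give only a minimum size, not a true one: the limit of > 4000 nM in this assay, at which 2 of the 4 values shown sit.

Only bromo and 1,1,2,2,2-pentafluoroethyl give numbers at this position. From the compounds shown here alone, whether an amine, a carboxylic acid or a longer perfluorinated chain would behave the same stays open.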